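A few compounds are considered here, and "the series" means these few. Any claim that something is new, unique, unknown or untested is made for them only; others in the source may bear on it.

Compound 1 `O=C1C(Nc2ccc(Br)cc2)=CC(=O)c2c1nc1n2[C@H]2OC[C@@H](O)[C@H]2OC1` carries a 4-bromophenyl group on an amine nitrogen attached to the shared core. In a functional assay on ECa-109 cells for inhibition, with ECa-109 cell line (Homo sapiens) as the target, read by sulforhodamine B assay (on this read-out higher numbers stand for weaker inhibition and lower numbers for stronger inhibition), compound 1 gives 1980 nM. Compound 3 `O=C1C=C(Nc2ccc(C(F)(F)F)cc2)C(=O)c2c1nc1n2[C@H]2OC[C@@H](O)[C@H]2OC1` carries a 4-(trifluoromethyl)phenyl group in the same place, and in this assay compound 3 gives 5500 nM. Compound 2 `COc1ccccc1NC1=CC(=O)c2nc3n(c2C1=O)[C@H]1OC[C@@H](O)[C@H]1OC3` has a 2-methoxyphenyl group there, and in this assay compound 2 reaches only a limit of the assay, > 4000 nM, not a number. Among the two numbers shown, compound 1 has the lowest; the nearest, from compound 3, is higher by more than the scatter. Within the data shown here, the only step between measured compounds, a step that the limit leaves unreadable from compound 2 to compound 3, cannot be sized because the limit of > 4000 nM in this assay, at which 1 of the 3 values shown sits, hides one end of it.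

Compound 4 `CCCc1ccc(NC2=CC(=O)c3c(nc4n3[C@H]3OC[C@@H](O)[C@H]3OC4)C2=O)cc1` differs from compound 1 in one place: propyl in place of bromo on an aromatic carbon. Among the measured compounds shown here, no measured step sizes a change of this kind, and the one step that touches the same phenyl group is unreadable, so nothing points to a movement beyond the scatter in either direction. Compound 4 is therefore expected to give about 2500 nM, within a range from 900 nM to 7000 nM. This estimate means a step of a 1.3-fold higher number from compound 1 to compound 4 (0.10 log units; within the scatter), expected to stay within the scatter.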

Compound 4, half-maximal inhibitory concentration: > 4000 nM
Compound 4: a limit, no number; the forecaster's own chance of this, stated with the estimate: 25%; middle value at least 1.6-fold (0.20 log units) away from the limit.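

Among these compounds, replacing bromo with propyl on this aromatic carbon, para to a large group, gives the only readable step that touches the substituent on the phenyl ring: an at least 2.0-fold higher number from compound 1 to compound 4 (0.30 log units; that floor lies within the scatter). The step has a floor rather than a measured size, and that floor does not by itself show a change beyond the usual scatter, so the result shows that a 4-propylphenyl group does not bring a lower number than the 4-bromophenyl group in this assay. In that assay, compound 4 reaches only a limit, > 4000 nM, not a number, and the comparisons that can be read in this small set stay few because so many compounds end at this limit: the limit of > 4000 nM in this assay, at which 2 of the 4 values shown sit.

As far as these compounds go, how far compound 4 lies past its limit cannot be told from these values, so the true size of the step from the bromo group to the propyl group remains unknown. Also open, from the compounds shown here alone, is whether a smaller group in the same place, such as methyl, chloro or an amine, would keep a number close to that of compound 1 or would also end at the limit.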